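A Second Aromatic Methyl on Compound 1

This account rests on a few compounds, and the source may have more. Where it says the series, first, only, none or still open, it means among the compounds named here.

Measured compounds:
compound 1, `CC1=NN(c2ccccc2)C(=O)[C@]12C(=O)C=CC[C@H]2c1ccc(C)cc1`, gives 4220 nM
compound 2, `CC1=NN(c2ccccc2)C(=O)[C@@]12C(=O)C=CC[C@H]2c1ccc(C)cc1`, gives 5210 nM
compound 3, `CC1=NN(c2ccccc2)C(=O)[C@@]12C(=O)C=CC[C@H]2c1ccccc1`, gives 4400 nM

All three were tested in a functional assay on HCT-116 cells (Homo sapiens) for inhibition, read by MTT assay, with a stated time of 72 h; a higher number here means a weaker inhibitor, a lower number a stronger inhibitor. Compound 1 and compound 2 share every atom and bond and are distinguished only by how one stereocentre is drawn, and the fact that compounds 1 and 2 differ only in the configuration as drawn is the only thing that separates them; the step of a 1.2-fold higher number from compound 1 to compound 2 (0.09 log units; within the scatter) stays within the scatter, so the two cannot be told apart in this assay. Compound 3 and compound 2 differ by methyl in place of hydrogen on an aromatic carbon, and that change produced a 1.2-fold higher number from compound 3 to compound 2 (0.07 log units; within the scatter), again within the scatter. Compound 1 and compound 3 differ in more than one place, and the difference between the two cores is not broken down here; compound 1 gives 4220 nM while compound 3 gives 4400 nM, and these lie within the scatter of each other.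

Compound 4, `CC1=NN(c2ccc(C)cc2)C(=O)[C@]12C(=O)C=CC[C@H]2c1ccc(C)cc1`, is not yet measured. Among the compounds with values here, it differs from compound 1 by methyl in place of hydrogen on an aromatic carbon, which is the same change as the one from compound 3 to compound 2, at the same kind of place. Because a 1.2-fold higher number from compound 3 to compound 2 (0.07 log units; within the scatter) stayed within the scatter, the step from compound 1 to compound 4 is expected to be small as well, estimated at a 1.1-fold higher number from compound 1 to compound 4 (0.06 log units; within the scatter). Compound 4 is therefore expected to give about 4800 nM, most likely between 2500 nM and 9500 nM.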

Compound 4, half-maximal inhibitory concentration: 3530 nM
Compound 4: the middle estimate sits 1.4-fold (0.13 log units) above what was measured; low and high end bracket the measured number.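

Going from phenyl to 4-methylphenyl on the core of compound 1 gives a 1.2-fold lower number from compound 1 to compound 4 (0.08 log units; within the scatter) in this assay, so this added methyl leaves no change that can be read in this assay. Set beside the earlier step, the result gives no sign that the change behaves differently on the two cores, and the opposite directions of the two small steps carry no meaning: the same change on two cores in this assay, a 1.2-fold higher number (0.07 log units; within the scatter) from compound 3 to compound 2 and a 1.2-fold lower number (0.08 log units; within the scatter) from compound 1 to compound 4, 1.4-fold (0.15 log units) apart, within the scatter of two such steps

This shows only that the methyl made no readable difference in either of these two settings, and it does not show how the change would carry to a core that is truly different, or how a change with a clear effect would carry, since the two cores here are close relatives: the fact that compounds 1 and 2 differ only in the configuration as drawn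

The compounds shown leave open whether a different group at this place on the ring, such as an amine, a carboxylic acid or a longer chain, would move the number beyond the scatter. Also open, on these data alone, is whether changes to other parts of the shared core, such as its carbonyl groups, would matter in this assay.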